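This account rests on a few compounds, and the source may have more. Where it says the series, first, only, none or still open, it means among the compounds named here.

Compounds measured so far in a functional assay on HepG2 cells (Homo sapiens) for antiproliferative activity, read by MTT assay, with a stated time of 24 h; a higher number here means a weaker inhibitor, a lower number a stronger inhibitor:

compound 1 `COc1ccc(C(=O)/C=C/c2ccc(Br)cc2)c2c1C=CC(C)(C)O2` – compound 1 gives > 10000 nM, which is a limit of the assay and not a number.
compound 2 `COc1ccc(C(=O)/C=C/c2ccc(N(C)C)cc2)c2c1C=CC(C)(C)O2` – compound 2 gives 730 nM.
compound 3 `COc1ccc(C(=O)/C=C/c2ccc(N(c3ccccc3)c3ccccc3)cc2)c2c1C=CC(C)(C)O2` – compound 3 gives > 10000 nM, again a limit of the assay.

Going by the values given here, compound 2 thus holds the only numerical value in this assay; the other two results sit at the limit of > 10000 nM in this assay, at which 2 of the 3 values shown sit. Among the compounds with values here, the one measured step is an at least 13-fold lower number from compound 1 to compound 2 (1.13 log units; beyond the scatter), so the dimethylamino group on the aromatic ring is the single change that has turned a limit into a number here. Compound 4 `COc1ccc(C(=O)/C=C/c2ccc([N+](=O)[O-])cc2)c2c1C=CC(C)(C)O2` carries nitro in place of dimethylamino on an aromatic carbon. Within the data shown here, no measured pair shows this particular exchange, and the only step available points in the opposite direction: replacing the substituent at this position once moved the value by a large amount, with the dimethylamino version the stronger inhibitor. Removing that group is therefore expected to cost potency rather than gain it. The step from compound 2 to compound 4 is estimated as an 11-fold higher number from compound 2 to compound 4 (1.04 log units; beyond the scatter). Compound 4 is expected to give about 8000 nM in this assay, within 2000 nM to 30000 nM, with a fair chance that only a limit is reported.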

Compound 4, half-maximal inhibitory concentration: 2610 nM
Beside the measured number, compound 4's estimate is 3.1-fold (0.49 log units) above it, within the range that was stated.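

In this assay the exchange of 4-(dimethylamino)phenyl for 4-nitrophenyl gives a 3.6-fold higher number from compound 2 to compound 4 (0.55 log units; beyond the scatter), so a numerical value persists without dimethylamino at this position, and the step is modest. Dimethylamino is therefore not the only group here that moves the result off the limit, as the change from bromo to nitro also shows, with an at least 3.8-fold lower number from compound 1 to compound 4 (0.58 log units; beyond the scatter). Compound 1 gives a limit of the assay and not a number, so the true size of that step stays open: the limit of > 10000 nM in this assay, at which 2 of the 4 values shown sit.

Going by these compounds, how a primary amine or a carboxylic acid on this aromatic carbon would compare with compound 2 and compound 4 remains open. Also open, on these data alone, is whether a dialkylamine with longer chains than dimethylamino would keep a numerical value, given that compound 3 gives only a limit of the assay.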